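Swapping a benzyl for a 3-methoxyphenyl on the amine

The compounds below may be only part of what the source reports. "The series", "measured", "known", "first", "only" and "open" are said of these compounds alone.

Compound 1 `O=C1C=C(NCc2ccccc2)C(=O)c2c1nc1n2[C@H]2OC[C@@H](O)[C@H]2OC1` is tested in a functional assay on MGC-803 cells (Homo sapiens) for inhibition, read by sulforhodamine B assay (a lower number here means a stronger inhibitor, a higher number a weaker inhibitor), where compound 1 gives 2670 nM. Among the measured compounds shown here, only two numbers exist, and compound 2 `Cc1ccc(NC2=CC(=O)c3c(nc4n3[C@H]3OC[C@@H](O)[C@H]3OC4)C2=O)cc1` with 1550 nM sits within the scatter of compound 1. Compound 3 `O=C1C(N2CCC2)=CC(=O)c2c1nc1n2[C@H]2OC[C@@H](O)[C@H]2OC1` gives > 16000 nM, a limit rather than a number, namely (the limit of > 16000 nM in this assay, at which 1 of the 3 values shown sits). For the measured compounds named here, the one measured step, an at least 10-fold higher number from compound 2 to compound 3 (1.01 log units; beyond the scatter), concerns an azetidin-1-yl replacing an arylamino and does not touch the change at hand. Compound 4 `COc1cccc(NC2=CC(=O)c3nc4n(c3C2=O)[C@H]2OC[C@@H](O)[C@H]2OC4)c1` differs from compound 1 by 3-methoxyphenyl in place of benzyl on an amine nitrogen. This makes compound 4 an arylamino like compound 2, whose 1550 nM is the closest guide. Compound 4 is therefore expected to land near compound 2, with a 1.5-fold lower number from compound 1 to compound 4 (0.17 log units; within the scatter), an estimated 1800 nM between 700 nM and 4500 nM.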

Compound 4, half-maximal inhibitory concentration: 1780 nM
Estimate against measurement, compound 4: 1.0-fold (0.00 log units) above; low and high end bracket the measured number.
By their numbers in this assay, from the lowest: compounds 2, 4 and 1 (each within the scatter of the next). At a limit, above all of these: compound 3.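

Read in this assay, this is the first measured step to link a benzylamino compound to an arylamino one, and it stays within the scatter: a 1.5-fold lower number from compound 1 to compound 4 (0.18 log units; within the scatter). On this amine nitrogen, then, the assay does not tell benzyl and 3-methoxyphenyl apart. Nothing shown offers a reason for this result.

Going by these compounds, whether a longer chain such as phenethyl, or a carboxylic acid on the aromatic ring, would move the number beyond the scatter stays open.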